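Swapping chloro for trifluoromethyl on the anilide ring

A few compounds are considered here, and "the series" means these few. Any claim that something is new, unique, unknown or untested is made for them only; others in the source may bear on it.

Three measured compounds share one core and differ only in the ring attached to the amide nitrogen. Compound 1 `COc1cc(-c2cc(C(=O)O)c3ccccc3n2)ccc1OCC(=O)Nc1ccc(C)cc1` carries a 4-methylphenyl group there. In an ADME assay on HaCaT cells (Homo sapiens) for inhibition (a lower number here means a stronger inhibitor, a higher number a weaker inhibitor), compound 1 gives only a limit, > 300000 nM, not a number. Compound 2 `COc1cc(-c2cc(C(=O)O)c3ccccc3n2)ccc1OCC(=O)Nc1cccc(F)c1` carries a 3-fluorophenyl group instead and gives 148000 nM in this assay. Compound 3 `COc1cc(-c2cc(C(=O)O)c3ccccc3n2)ccc1OCC(=O)Nc1cccc(Cl)c1` carries a 3-chlorophenyl group and gives 192000 nM in this assay. Among the measured compounds shown here, compound 3 and compound 2 are the only two with a number rather than a limit, and they differ by a 1.3-fold higher number from compound 2 to compound 3 (0.11 log units; within the scatter), so they stand together. Compound 1 sits at the limit of > 300000 nM in this assay, at which 1 of the 3 values shown sits.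

Compound 4 `COc1cc(-c2cc(C(=O)O)c3ccccc3n2)ccc1OCC(=O)Nc1cccc(C(F)(F)F)c1` differs from compound 3 in one place: trifluoromethyl in place of chloro on an aromatic carbon. For the measured compounds named here, the step that bears most on this is the one from compound 2 to compound 3, a 1.3-fold higher number from compound 2 to compound 3 (0.11 log units; within the scatter), where one halogen replaced another without a change beyond the scatter. The steps of an at least 2.0-fold lower number from compound 1 to compound 2 (0.30 log units; that floor lies within the scatter) and an at least 1.5-fold lower number from compound 1 to compound 3 (0.19 log units; that floor lies within the scatter) start from a limit and only set a floor. Exchanging chloro for trifluoromethyl is therefore expected to leave the number roughly where it is, so the step from compound 3 to compound 4 in this assay is estimated as a 1.0-fold higher number from compound 3 to compound 4 (0.02 log units; within the scatter). Compound 4 is expected at about 200000 nM in this assay, between 90000 nM and 300000 nM, with a fair chance that it is reported only as a limit.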

Compound 4, half-maximal inhibitory concentration: 160000 nM
Compound 4: middle estimate off by 1.3-fold (0.10 log units), on the high side; the range from low to high includes it.
By their numbers in this assay, from the lowest: compounds 2, 4 and 3 (each within the scatter of the next). At a limit, above all of these: compound 1.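

In this assay, trifluoromethyl brings 4 heavy atoms where chloro brings 1, yet the number does not move beyond the scatter, either for a 1.2-fold lower number from compound 3 to compound 4 (0.08 log units; within the scatter) or for a 1.1-fold higher number from compound 2 to compound 4 (0.03 log units; within the scatter). Compounds 2, 3 and 4 therefore stand together, so the match first seen between two halogens now extends to a group that is not a single halogen, while an at least 1.8-fold lower number from compound 1 to compound 4 (0.27 log units; that floor lies within the scatter) is only a floor that starts from a limit. Compound 1 still gives a limit and not a number: the limit of > 300000 nM in this assay, at which 1 of the 4 values shown sits.

The 4-methylphenyl group of compound 1 differs from the other three rings in both the group and its place on the ring, so these compounds cannot show which of the two matters. Going by these compounds, it also remains open whether a group of a different kind at this ring carbon, such as an amine, a hydroxyl or a carboxylic acid, would shift the number beyond the scatter.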